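This account rests on a few compounds, and the source may have more. Where it says the series, first, only, none or still open, it means among the compounds named here.

Series notes. For the measured compounds named here, compound 1 `COc1ccc(/C=C\C(=O)O)c(OCc2cn(-c3ccccc3I)nn2)c1CC=C(C)C` gives 2200 nM in a functional assay on A549 cells (Homo sapiens) for cytotoxicity, read by MTT assay, with a stated time of 24 h (a higher number here means a weaker inhibitor, a lower number a stronger inhibitor), the lowest of the three numbers measured so far. Compound 2 `COc1ccc(/C=C\C(=O)O)c(OCc2cn(-c3ccccc3C#N)nn2)c1CC=C(C)C` gives 38600 nM and compound 3 `COc1cccc(-n2cc(COc3c(/C=C\C(=O)O)ccc(OC)c3CC=C(C)C)nn2)c1` gives 42700 nM in this assay; the two steps from the lowest number are both large: an 18-fold higher number from compound 1 to compound 2 (1.24 log units; beyond the scatter) and a 19-fold higher number from compound 1 to compound 3 (1.29 log units; beyond the scatter). Between the other two the step is a 1.1-fold higher number from compound 2 to compound 3 (0.04 log units; within the scatter). Compound 4 `COc1ccc(/C=C\C(=O)O)c(OCc2cn(-c3cccnc3Cl)nn2)c1CC=C(C)C` is not yet measured. It differs from compound 1 by 2-chloropyridin-3-yl in place of 2-iodophenyl on an aromatic nitrogen. Going by the values given here, both measured steps replaced the 2-iodophenyl on the aromatic nitrogen and both gave a large increase, so an upward step in this assay is expected for compound 4 as well, though no measured step toward a 2-chloropyridin-3-yl exists to fix its size. The expected step is a 4.1-fold higher number from compound 1 to compound 4 (0.61 log units; beyond the scatter). For compound 4 a value of 9000 nM is estimated, within 2500 nM to 30000 nM.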

Compound 4, half-maximal inhibitory concentration: 5600 nM
The estimate for compound 4 lay 1.6-fold (0.21 log units) above the measured number; measured number inside the range.
By their numbers in this assay, from the lowest: compound 1; then compound 4; then compounds 2 and 3 (each within the scatter of the next).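

In this assay, the 2-iodophenyl on the aromatic nitrogen can be replaced at a much smaller cost than the earlier changes showed: a 2.5-fold higher number from compound 1 to compound 4 (0.41 log units; beyond the scatter) is only a modest rise. The 2-chloropyridin-3-yl group also separates from the other two replacements (a 7.6-fold lower number from compound 3 to compound 4 (0.88 log units; beyond the scatter) and a 6.9-fold lower number from compound 2 to compound 4 (0.84 log units; beyond the scatter)), so the outcome at this position depends on the replacing group, with compound 1 still lowest. No evidence available here accounts for these differences. Open: whether the chlorine or the ring nitrogen carries the difference, and how an amine on that ring would read.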